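From Methyl to Methoxy on an Aromatic Carbon

The compounds below may be only part of what the source reports. "The series", "measured", "known", "first", "only" and "open" are said of these compounds alone.

- Compound 1 `Cc1ccc(-c2cc3nc(N)[nH]c(=O)c3s2)cc1`: "nd(insoluble)" (no result reported)
- Compound 2 `Cc1ccc(-c2csc3c(=O)[nH]c(NC(C)(C)C)nc23)cc1`: 1400 nM
- Compound 3 `Cc1ccc(-c2csc3c(=O)[nH]c(NC(C)C)nc23)cc1`: 8800 nM

In an ADME assay on HepG2 cells (Homo sapiens) for cytotoxicity, read by MTT assay, with a stated time of 72 h (a higher number here means that more compound is tolerated, a lower number that less compound is tolerated), compound 3 gives 8800 nM, the higher of the two numbers available, while compound 1 gave no number at all. Compound 4 `COc1ccc(-c2csc3c(=O)[nH]c(NC(C)C)nc23)cc1` has the same structure as compound 3 except for methoxy in place of methyl on an aromatic carbon.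

Among the measured compounds shown here, only one measured step exists, a 6.3-fold higher number from compound 2 to compound 3 (0.80 log units; beyond the scatter). It replaces a methyl with hydrogen on a saturated chain carbon, at a different place in the molecule. For the measured compounds named here, it shows that this assay can respond to a small edit, but it says nothing direct about this swap, and no measured compound carries methoxy. With no evidence for a direction, no shift beyond the scatter is expected, and the estimated change is a 1.3-fold lower number from compound 3 to compound 4 (0.10 log units; within the scatter). The uncertainty stays wide. For compound 4 the expected value is 7000 nM, with an expected range from 2500 nM to 20000 nM.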

Compound 4, half-maximal cytotoxic concentration: 27800 nM
Compound 4: the middle estimate sits 4.0-fold (0.60 log units) below what was measured, and the stated range ends below it.
By their numbers in this assay, from the lowest: compound 2; then compound 3; then compound 4.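

In this assay the step of a 3.2-fold higher number from compound 3 to compound 4 (0.50 log units; beyond the scatter) shows that the tolerated concentration responds to a change at this place on the six-membered aromatic ring of carbon only, para to a large group. Among the compounds shown here, until now, the only measured step was at a different place, on the saturated chain, so this is the first sign that the aromatic end of the molecule also matters. The edit is small, adding one oxygen and one hydrogen-bond acceptor, yet its step lies beyond the scatter, and nothing available here bears on why this happens.

From the compounds shown here alone, it remains open whether other groups at this place, such as a hydroxyl, an amine or a chlorine atom, would move the number in the same direction. Going by these compounds, whether methoxy would have a similar effect on the chain of compound 2 is also open.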